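Methoxy in place of trifluoromethyl on the shared core

The source may report more compounds than this note shows. Statements on the series, on what has been measured and on what is new or still open speak of the compounds shown alone.

Compound 1 `Cc1cc(C)c2ccc(=O)n(CCN(C)C)c2n1` gives 3.93 ug/mL in an assay on isolated protein (strain Charles River) for antagonist activity at histamine H2 receptor (Rattus norvegicus); a lower number here means that less compound is needed, a higher number that more compound is needed for the effect. Compound 2 `Cc1cc(C(F)(F)F)nc2c1ccc(=O)n2CCN(C)C` carries a trifluoromethyl on the same core where a methyl stands in the first compound; in this assay compound 2 gives 1.6 ug/mL. The step of a 2.5-fold lower number from compound 1 to compound 2 (0.39 log units; beyond the scatter) is modest but beyond the scatter. Compound 2 therefore stands with the lowest of the two numbers, its nearest neighbour being compound 1 at a higher number.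

Compound 3 `COc1cc(C)c2ccc(=O)n(CCN(C)C)c2n1` has not been measured. It differs from compound 2 by methoxy in place of trifluoromethyl on an aromatic carbon. Going by the values given here, the only step that bears on this position is the one from compound 1 to compound 2, in which the trifluoromethyl lowered the number modestly relative to the methyl. Methoxy is a third group at the same place and matches neither, so no measured step shows its effect directly; the safest reading is a number near compound 2 or drifting back toward compound 1, with the step of a 1.8-fold higher number from compound 2 to compound 3 (0.24 log units; within the scatter) expected to stay small. Compound 3 is estimated at 2.8 ug/mL, within 1.2 ug/mL to 6.5 ug/mL.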

Compound 3, half-maximal effective concentration: 7.01 ug/mL
Estimate against measurement, compound 3: 2.5-fold (0.40 log units) below; the measured number lies above the stated range.
By their numbers in this assay, from the lowest: compound 2; then compounds 1 and 3 (each within the scatter of the next).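

Working notes on this position: in this assay, methoxy in place of trifluoromethyl gives a 4.4-fold higher number from compound 2 to compound 3 (0.64 log units; beyond the scatter), so the lower number of compound 2 does not carry over to this second replacement of trifluoromethyl on the aromatic carbon next to the ring nitrogen. Methoxy in place of methyl gives a 1.8-fold higher number from compound 1 to compound 3 (0.25 log units; within the scatter), which leaves compound 1 and compound 3 indistinguishable here, even though methoxy brings a hydrogen-bond acceptor that methyl lacks. Among the three groups tested at this place, only trifluoromethyl therefore stands apart, with its steps to both methyl and methoxy beyond the scatter, and nothing at hand accounts for this difference.

As far as these compounds go, whether a chlorine, a nitrile or an amine on this aromatic carbon would give a number close to that of compound 2 or fall with compound 1 and compound 3 remains open. Also open, from the compounds shown here alone, is whether the gap between trifluoromethyl and the other two groups would persist with a longer chain in place of the dimethylaminoethyl chain shared by all three compounds.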